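Replacing 4-chlorobenzyl with 3-(pyridin-3-yl)propyl

The source may hold more compounds than are shown below. What is called first, only, known or untested is meant among the compounds shown, and "the series" means these compounds.

Measured values in a functional assay on NCI-H460 cells (Homo sapiens) for inhibition, read by sulforhodamine B assay, with a stated time of 48 h (a higher number here means a weaker inhibitor of growth, a lower number a stronger inhibitor of growth), follow
Compound 1 (`Clc1ccc(Cn2cc(CCCOc3cccc4cccnc34)nn2)cc1`) gives 11.2 ug/mL
Compound 2 (`Fc1ccc(Cn2cc(CCCOc3cccc4cccnc34)nn2)cc1F`) gives 23.7 ug/mL
Compound 3 (`Clc1cc(Cl)c(Cn2cc(CCCOc3cccc4cccnc34)nn2)c(Cl)c1`) gives 7.4 ug/mL

Compound 1 stands level with one neighbour (a 1.5-fold lower number from compound 1 to compound 3 (0.18 log units; within the scatter)) and apart from the other (a 2.1-fold higher number from compound 1 to compound 2 (0.33 log units; beyond the scatter)). Compound 4 (`c1cncc(CCCn2cc(CCCOc3cccc4cccnc34)nn2)c1`) differs from it in one place, on a saturated chain carbon bound to an aromatic nitrogen (2-(pyridin-3-yl)ethyl in place of 4-chlorophenyl on a saturated chain carbon bound to an aromatic nitrogen), where 4-chlorobenzyl becomes 3-(pyridin-3-yl)propyl. The measured steps bear on this only loosely, since each swaps one halogen-carrying phenyl group for another, and the largest is modest (a 3.2-fold lower number from compound 2 to compound 3 (0.51 log units; beyond the scatter)). None of them brings in a ring with a hetero atom. Compound 4 carries no chlorine, and neither does compound 2 (23.7 ug/mL), so a small rise in the number in this assay is expected rather than a large one. The estimated step is correspondingly modest (a 1.8-fold higher number from compound 1 to compound 4 (0.25 log units; within the scatter)). The expected value for compound 4 is (20 ug/mL), with an estimated range from (8 ug/mL) to (45 ug/mL).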

Compound 4, concentration for 50% growth inhibition: 44.3 ug/mL
Estimate against measurement, compound 4: 2.2-fold (0.35 log units) below, and the stated range covers the measured number.
By their numbers in this assay, from the lowest: compounds 3 and 1 (each within the scatter of the next); then compounds 2 and 4 (each within the scatter of the next).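

At this position, on a saturated chain carbon bound to an aromatic nitrogen, the first ring with a hetero atom gives a weaker result in this assay than either chlorine-carrying group (a 4.0-fold higher number from compound 1 to compound 4 (0.60 log units; beyond the scatter); a 6.0-fold higher number from compound 3 to compound 4 (0.78 log units; beyond the scatter)). Set against 3,4-difluorophenyl, the same swap makes no real difference (a 1.9-fold higher number from compound 2 to compound 4 (0.27 log units; within the scatter)), so this group offers no gain over the one other chlorine-free group shown. Nothing measured here explains these steps, and the ring and the chain length change together in this single swap.

The compounds leave open whether the ring nitrogen or the longer chain matters more, which a plain phenyl ring on the same propyl chain would help to separate. As far as these compounds go, how an amine or a carboxylic acid at this place would behave also remains open.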